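This account rests on a few compounds, and the source may have more. Where it says the series, first, only, none or still open, it means among the compounds named here.

Measured so far:
compound 1, `C#Cc1cn([C@@H]2O[C@H](CO)[C@@H](O)[C@H]2O)c2nc(C)nc(N)c12` — 3290 nM
compound 2, `Cc1nc(N)c2c(-c3ccsc3)cn([C@@H]3O[C@H](CO)[C@@H](O)[C@H]3O)c2n1` — reported as a limit only
compound 3, `C#Cc1cn([C@@H]2O[C@H](CO)[C@@H](O)[C@H]2O)c2ncnc(SC)c12` — 70 nM

In a functional assay on K562 cells (Homo sapiens), read by MTT assay, with a stated time of 72 h (a lower number here means a stronger inhibitor, a higher number a weaker inhibitor), compound 1 gives 3290 nM. For compound 2 the assay reports no number but a limit, > 20000 nM. Compound 3 gives 70 nM and stands lowest of the two numbers shown, the nearest being compound 1, a gap beyond the scatter. How the core of compound 3 differs from the core of compound 1 is not broken down here.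

For the measured compounds named here, the one measured step within a shared core is the change (thiophen-3-yl in place of ethynyl on an aromatic carbon), which made an at least 6.0-fold higher number from compound 1 to compound 2 (0.78 log units; beyond the scatter). Its size is open upward because of the limit of > 20000 nM in this assay, at which 1 of the 3 values shown sits.

Compound 4, `CSc1ncnc2c1c(-c1ccsc1)cn2[C@@H]1O[C@H](CO)[C@@H](O)[C@H]1O`, is not yet measured in this assay. It arises from compound 3 by the same change, (thiophen-3-yl in place of ethynyl on an aromatic carbon), made on the same kind of position as in the first pair. The step from compound 3 to compound 4 is therefore expected to be a 13-fold higher number from compound 3 to compound 4 (1.11 log units; beyond the scatter), set beside the measured one, an at least 6.0-fold higher number from compound 1 to compound 2 (0.78 log units; beyond the scatter), and resting on that single pair alone; since that pair ends at a limit, the true size of the step there is not known, and only one such pair exists among the compounds shown. Compound 4 is expected to give about 900 nM in this assay, with a likely range of 250 nM to 4000 nM.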

Compound 4, half-maximal inhibitory concentration: > 20000 nM
Compound 4: a limit, no number (the forecaster's own chance of this, stated with the estimate: 5%); middle value at least 22-fold (1.34 log units) from the limit.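

Carrying thiophen-3-yl in place of ethynyl onto the core of compound 3 gives, in this assay, an at least 280-fold higher number from compound 3 to compound 4 (2.45 log units; beyond the scatter). On both cores the change moves the number in the same direction, which shows that the loss seen on the core of compound 1 also appears on the core of compound 3, while the sizes of the two steps cannot be compared: the same change on two cores in this assay, an at least 6.0-fold higher number (0.78 log units; beyond the scatter) from compound 1 to compound 2 and an at least 280-fold higher number (2.45 log units; beyond the scatter) from compound 3 to compound 4; the limit leaves it open whether they differ. Compound 2 and compound 4 are both reported only as limits, so the direction carries from one core to the other, but no size for the change is established on either core and no difference between the cores in their response to it can be read: the limit of > 20000 nM in this assay, at which 2 of the 4 values shown sit.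

Only ethynyl and thiophen-3-yl appear on this aromatic carbon among the compounds shown, so it remains open whether a group such as methyl, nitrile, an amine or a phenyl ring there would keep the number near that of compound 3, at 70 nM. The cores of compound 1 and compound 3 differ in more than one place, and the compounds shown leave open which of those differences matters in this assay.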